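This account rests on a few compounds, and the source may have more. Where it says the series, first, only, none or still open, it means among the compounds named here.

Measured so far in an assay on mitochondria from L6 cells (Rattus norvegicus) for activation, with a stated time of 90 min; a higher number here means that more compound is needed for the effect, a lower number that less compound is needed:
compound 1 `Fc1ccccc1Nc1nc2nonc2nc1NC1CCCCC1`: 13400 nM
compound 2 `Fc1cccc(Nc2nc3nonc3nc2Nc2ccccc2F)c1`: 190 nM
compound 3 `Cc1cccc(Nc2nc3nonc3nc2Nc2ccccc2F)c1`: 1500 nM

Compound 3 holds the second highest of the three numbers in this assay. Its nearest neighbour is compound 2, a 7.9-fold higher number from compound 2 to compound 3 (0.90 log units; beyond the scatter); its furthest is compound 1, an 8.9-fold lower number from compound 1 to compound 3 (0.95 log units; beyond the scatter). The third measured step, a 71-fold lower number from compound 1 to compound 2 (1.85 log units; beyond the scatter), concerns the same position on the same nitrogen as the other two.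

Compound 4 `COc1cccc(Nc2nc3nonc3nc2Nc2ccccc2F)c1` is not yet measured. It differs from compound 3 in one place: methoxy in place of methyl on an aromatic carbon. The change sits on an aromatic carbon of a six-membered aromatic ring of carbon only, meta to a large group, the same ring where fluoro and methyl were compared in a 7.9-fold higher number from compound 2 to compound 3 (0.90 log units; beyond the scatter). That step is the only one that bears on a change at this position, and it was of modest size. Going by the values given here, no measured pair compares methyl with methoxy, so the direction of the new step is unknown from the data. Compound 4 is therefore expected to stay close to compound 3 in this assay, with a 1.2-fold higher number from compound 3 to compound 4 (0.08 log units; within the scatter) as the estimated step. The estimate for compound 4 is 1800 nM, with the range 500 nM to 6000 nM.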

Compound 4, half-maximal effective concentration: 830 nM
Beside the measured number, compound 4's estimate is 2.2-fold (0.34 log units) above it; measured number inside the range.
By their numbers in this assay, from the lowest: compound 2; then compounds 4 and 3 (each within the scatter of the next); then compound 1.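

In this assay, methoxy and methyl cannot be told apart on this aromatic carbon, with a 1.8-fold lower number from compound 3 to compound 4 (0.26 log units; within the scatter), so adding the oxygen to the substituent gives no readable shift relative to the methyl compound. Fluoro now stands apart from two other groups rather than one: a 4.4-fold higher number from compound 2 to compound 4 (0.64 log units; beyond the scatter) joins a 7.9-fold higher number from compound 2 to compound 3 (0.90 log units; beyond the scatter), and both steps are beyond the scatter, while the gain from replacing cyclohexyl holds for a third aryl partner, with a 16-fold lower number from compound 1 to compound 4 (1.21 log units; beyond the scatter), and no compound shown goes against it. Nothing available here accounts for these differences, as no supporting measurement bears on them.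

Open, going by these compounds, is how chloro, hydroxyl, an amine, a carboxylic acid or a longer chain such as ethoxy would read on this same aromatic carbon, and so whether fluoro's separation from methyl and methoxy is specific to fluoro or shared with other groups. Also open is whether these steps would keep their size if the fluorinated ring common to all four compounds were changed, since every comparison shown rests on that one partner and on this assay alone.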